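Swapping carboxy for hydroxy on a sulfonyl-linked ring

This account rests on a few compounds, and the source may have more. Where it says the series, first, only, none or still open, it means among the compounds named here.

Measured so far in a functional assay on K562 cells (Homo sapiens) for inhibition, read by trypan blue exclusion, with a stated time of 72 h (on this read-out higher numbers stand for weaker inhibition and lower numbers for stronger inhibition), are these two compounds.

Compound 1 `Cn1c(=O)c(S(=O)(=O)c2ccc(C(=O)O)cc2)cc2cnc(Nc3ccc4[nH]ccc4c3)nc21` (5000 nM)
Compound 2 `Cn1c(=O)c(S(=O)(=O)c2ccc(F)cc2)cc2cnc(Nc3ccc4occc4c3)nc21` (5000 nM)

Compound 1 stands level with compound 2, and neither stands apart in this assay on these numbers. The two differ in more than one place, so no single structural change has yet been measured on its own.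

Compound 3 `Cn1c(=O)c(S(=O)(=O)c2ccc(O)cc2)cc2cnc(Nc3ccc4[nH]ccc4c3)nc21` keeps the core of compound 1 and changes one group, with hydroxy in place of carboxy on an aromatic carbon. The same difference reads as 4-carboxyphenyl to 4-hydroxyphenyl, and it sits para to a large group.

For the measured compounds named here, with no measured step as a guide, a modest move toward stronger inhibition is expected, and it may stay within the scatter. Caution comes from compound 2, which has no carboxy group yet gives 5000 nM in this assay and so offers no sign of a large gain. The expected change is a 2.5-fold lower number from compound 1 to compound 3 (0.40 log units; beyond the scatter) and remains only an estimate. Compound 3 is estimated at 2000 nM (range 400 nM to 7000 nM).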

Compound 3, half-maximal inhibitory concentration: 100 nM
Compound 3: the middle estimate sits 20-fold (1.30 log units) above what was measured, and the stated range ends above it.
By their numbers in this assay, from the lowest: compound 3; then compounds 1 and 2 (each within the scatter of the next).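

Exchanging carboxy for hydroxy on an aromatic carbon, para to a large group, gives in this assay a 50-fold lower number from compound 1 to compound 3 (1.70 log units; beyond the scatter), so the group at this position can strongly change the read-out on the core of compound 1. For the compounds shown here, compound 1 and compound 2 could not show this, as they stand level but differ in more than one place, and this pair is the first to isolate a single change. Carboxy and hydroxy have the same counted hydrogen-bond donors and acceptors and neither carries a net charge, while carboxy has 3 heavy atoms against 1 for hydroxy, but no measurement here explains a step of this size.

One pair cannot tell whether the gain comes from having hydroxy at this position or simply from losing carboxy, and compounds carrying a methoxy group, an amine or plain hydrogen there would help to separate the two. As far as these compounds go, whether the same exchange acts alike when the rest of the molecule differs, as it does in compound 2, also remains open.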